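A few compounds are considered here, and "the series" means these few. Any claim that something is new, unique, unknown or untested is made for them only; others in the source may bear on it.

In an ADME assay on RAW264.7 cells (Mus musculus) for cytotoxicity, read by MTT assay, with a stated time of 48 h (on this read-out lower numbers stand for higher toxicity in this test and higher numbers for lower toxicity in this test), three compounds have been measured so far, and all three share the same core, carrying a propargyl chain and a cyclohexyl group on the nitrogen attached to it. Compound 1 `C#CCN(c1nc(-c2cccc(Br)c2)no1)C1CCCCC1` gives 31.8 ug/mL in this assay. Compound 2 `C#CCN(c1nc(-c2ccccc2)no1)C1CCCCC1` gives 32.1 ug/mL. The step between them, a 1.0-fold higher number from compound 1 to compound 2 (0.00 log units; within the scatter), removed a bromo group from an aromatic carbon and left the number essentially where it was. Compound 3 `CC(=O)OC[C@H]1O[C@H](OC[C@@H](Cn2cc(CN(c3nc(-c4ccc(Cl)cc4)no3)C3CCCCC3)nn2)OC(C)=O)C=C[C@@H]1OC(C)=O` carries a much larger substituent on the nitrogen in place of the propargyl chain and gives 35.5 ug/mL in this assay; it stands together with compound 1 and compound 2, its gap to each of them lying within the scatter.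

Compound 4 `CC(=O)OC[C@H]1O[C@H](OC[C@@H](Cn2cc(CN(c3nc(-c4ccc(Br)cc4)no3)C3CCCCC3)nn2)OC(C)=O)C=C[C@@H]1OC(C)=O` is the next compound to be measured in this assay. It differs from compound 3 in one place: bromo in place of chloro on an aromatic carbon. No measured step swaps one halogen for another; the only halogen step shown, from compound 1 to compound 2, exchanged bromo for hydrogen and was within the scatter. Since changing a halogen to hydrogen moved nothing, an exchange of chloro for bromo is also expected to stay within the scatter. Compound 4 is therefore estimated at 34 ug/mL, with a range from 20 ug/mL to 60 ug/mL. This estimate corresponds to an expected step of a 1.0-fold lower number from compound 3 to compound 4 (0.02 log units; within the scatter).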

Compound 4, half-maximal cytotoxic concentration: 39.1 ug/mL
The estimate for compound 4 lay 1.2-fold (0.06 log units) below the measured number; low and high end bracket the measured number.
By their numbers in this assay, from the lowest: compounds 1, 2, 3 and 4 (each within the scatter of the next).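

In this assay, among these compounds, the step of a 1.1-fold higher number from compound 3 to compound 4 (0.04 log units; within the scatter) is the first direct exchange of one halogen for another, made on an aromatic carbon para to a large group. The earlier bromo step instead replaced bromo with hydrogen in compounds that carry the small propargyl chain, so this result extends the picture to a different kind of change on a compound with the much larger substituent: going from 4-chlorophenyl to 4-bromophenyl stays within the usual scatter of this test, and compound 3 and compound 4 cannot be told apart by their numbers. No measurement is available that would explain why this exchange leaves the read-out within the scatter.

From the compounds shown here alone, this pair covers only chloro and bromo at this position on the larger compounds, so it remains open whether a plain hydrogen, an amine or a carboxylic acid there would also stay within the scatter. The cyclohexyl group is also the same in all four compounds, which leaves open what a linear hexyl chain or a smaller ring in its place would do to the number.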